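This account rests on a few compounds, and the source may have more. Where it says the series, first, only, none or still open, it means among the compounds named here.

Of the compounds shown here, two that share one core have been measured in a functional assay on HeLa cells (Homo sapiens) for inhibition, read by sulforhodamine B assay; a higher number here means a weaker inhibitor, a lower number a stronger inhibitor. Compound 1 `O=C1C(NC2CCCC2)=CC(=O)c2c1nc1n2[C@H]2OC[C@@H](O)[C@H]2OC1` carries a cyclopentyl group on an amine nitrogen. In this assay compound 1 gives > 16000 nM, which is a limit of the assay and not a number (the limit of > 16000 nM in this assay, at which 1 of the 2 values shown sits). Compound 2 `O=C1C=C(Nc2ccc(Br)cc2)C(=O)c2c1nc1n2[C@H]2OC[C@@H](O)[C@H]2OC1` instead carries an aromatic ring bearing a bromine on that nitrogen, and in this assay compound 2 gives 3830 nM. Compound 3 `O=C1C(Nc2cccc(F)c2)=CC(=O)c2c1nc1n2[C@H]2OC[C@@H](O)[C@H]2OC1` has not yet been measured; it differs from compound 1 by 3-fluorophenyl in place of cyclopentyl on an amine nitrogen. As compound 2 shows that an aromatic ring at this position can give a measurable number, the move from compound 1 to compound 3 is expected to be a step toward stronger inhibition, an at least 3.2-fold lower number from compound 1 to compound 3 (0.50 log units; beyond the scatter), though a limit remains possible. In this assay compound 3 is estimated at 5000 nM, with a likely range from 1500 nM to 16000 nM.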

Compound 3, half-maximal inhibitory concentration: > 8000 nM
Compound 3 gave a limit, no number; the forecaster's own chance of this, stated with the estimate: 30%; at least 1.6-fold (0.20 log units) between middle value and limit.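

Within the data shown here, compound 1 and compound 3 each end at a limit of the assay rather than a number, so no step between them can be read. The compounds shown leave open whether 3-fluorophenyl in place of cyclopentyl strengthens or weakens inhibition in this assay.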